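Changing the Ring on the Aromatic Nitrogen

A few compounds are considered here, and "the series" means these few. Any claim that something is new, unique, unknown or untested is made for them only; others in the source may bear on it.

Measured so far:
compound 1 `C=CCc1ccc(OCc2cn(-c3ccc(OC)cc3)nn2)c(O)c1` — 49.9%
compound 2 `C=CCc1ccc(OCc2cn(-c3ccccc3CO)nn2)c(O)c1` — 8.5%

Both compounds were tested in a functional assay on HepG2 cells (Homo sapiens) for inhibition, read by MTT assay, with a stated time of 72 h, tested at 50 uM; on this read-out lower numbers stand for less inhibition of growth and higher numbers for more inhibition of growth at the one concentration tested. Among the measured compounds shown here, of the two numbers, compound 2 stands lowest; its only neighbour is compound 1, and the step of a number 41.4 percentage points lower from compound 1 to compound 2 (beyond the scatter) lies well beyond the scatter. Compound 3 `C=CCc1ccc(OCc2cn(-c3cccc(C#N)c3)nn2)c(O)c1` has not yet been measured. It differs from compound 2 in one place: 3-cyanophenyl in place of 2-(hydroxymethyl)phenyl on an aromatic nitrogen. For the measured compounds named here, the single measured step that bears on this change is a number 41.4 percentage points lower from compound 1 to compound 2 (beyond the scatter), which shows that exchanging the ring on that aromatic nitrogen can move the read-out by a large amount. Compound 3 removes the 2-(hydroxymethyl)phenyl that compound 2 carries, and in the measured pair that very group went with the lowest number. Going by the values given here, the direction of the coming step is therefore expected to be upward, but no measured step tells how a 3-cyanophenyl behaves, so the size is uncertain and the range is wide. Compound 3 is expected to give about 30% in this assay, between 5% and 55%. This estimate for compound 3 corresponds to an expected step of a number 21.5 percentage points higher from compound 2 to compound 3 (beyond the scatter).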

Compound 3, percent growth inhibition at one concentration: 3.4%
The estimate for compound 3 lay 26.6 percentage points above the measured number, and the stated range ends above it.
By their numbers in this assay, from the lowest: compounds 3 and 2 (each within the scatter of the next); then compound 1.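

In this assay, the exchange of ring on the aromatic nitrogen gives a number 5.1 percentage points lower from compound 2 to compound 3 (within the scatter), so these two rings cannot be told apart here, although the leaving 2-(hydroxymethyl)phenyl has 1 hydrogen-bond donor and the entering 3-cyanophenyl has 0. Set against the 4-methoxyphenyl ring, the new compound gives a number 46.5 percentage points lower from compound 1 to compound 3 (beyond the scatter), a large step, so the low read-out is no longer tied to 2-(hydroxymethyl)phenyl alone: two differently substituted rings now share it, and among the three compounds only the one with 4-methoxyphenyl stands apart. No measurement at hand explains why the 4-methoxyphenyl compound differs from the other two.

The three rings each carry a different group, so the compounds shown do not tell whether the methoxy group itself goes with the higher number or whether the other two groups go with the lower numbers. A plain phenyl ring would help to separate these cases, and rings carrying an amine or a carboxylic acid would show how much wider the range at this position can be in this assay.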